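Benzoxazole anilide amines: side-chain shortening on the fluoro core

A few compounds are considered here, and "the series" means these few. Any claim that something is new, unique, unknown or untested is made for them only; others in the source may bear on it.

In a functional assay on A549 cells (Homo sapiens) for cytotoxicity, read by MTT assay, with a stated time of 24 h (a higher number here means a weaker inhibitor, a lower number a stronger inhibitor), compound 2 `Cc1cc(-c2nc3ccccc3o2)ccc1NC(=O)CN1CCN(CCCN(C)C)CC1` gives 22100 nM. Compound 1 `Cc1cc(-c2nc3ccccc3o2)ccc1NC(=O)CN1CCN(CCN(C)C)CC1` differs from it by dimethylamino in place of (dimethylamino)methyl on a saturated chain carbon, two bonds along the chain from an amine nitrogen in a ring and gives 30500 nM; the step is a 1.4-fold higher number from compound 2 to compound 1 (0.14 log units; within the scatter). Compound 3 `Cc1cc(-c2nc3cc(F)ccc3o2)ccc1NC(=O)CN1CCN(CCCN(C)C)CC1` gives 12200 nM, with the step of a 1.8-fold lower number from compound 2 to compound 3 (0.26 log units; within the scatter). Compound 3 has the lowest number of the three measured; the gap to compound 2 lies within the scatter, the gap to compound 1 beyond it, so no order among compound 2 and compound 3 is claimed.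

Compound 4 `Cc1cc(-c2nc3cc(F)ccc3o2)ccc1NC(=O)CN1CCN(CCN(C)C)CC1` has not been measured. It differs from compound 3 by dimethylamino in place of (dimethylamino)methyl on a saturated chain carbon, two bonds along the chain from an amine nitrogen in a ring, the same change, at the same place, that turns compound 2 into compound 1; the change occurs in two pairs among the compounds shown. The cores of the two pairs differ by fluoro in place of hydrogen on an aromatic carbon.

Going by the values given here, for this assay the step from compound 3 to compound 4 is expected to be a 1.4-fold higher number from compound 3 to compound 4 (0.14 log units; within the scatter), because a 1.4-fold higher number from compound 2 to compound 1 (0.14 log units; within the scatter), the single measured instance of this change, stayed within the scatter. Compound 4 is therefore estimated at 17000 nM, expected between 8000 nM and 36000 nM.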

Compound 4, half-maximal inhibitory concentration: 7370 nM
The estimate for compound 4 lay 2.3-fold (0.36 log units) above the measured number, and the stated range ends above it.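

In this assay, going by these compounds alone, the change from 3-(dimethylamino)propyl to 2-(dimethylamino)ethyl on the core of compound 3 gives a 1.7-fold lower number from compound 3 to compound 4 (0.22 log units; within the scatter), and this step cannot be told apart from its earlier counterpart on the core of compound 1: the same change on two cores in this assay, a 1.4-fold higher number (0.14 log units; within the scatter) from compound 2 to compound 1 and a 1.7-fold lower number (0.22 log units; within the scatter) from compound 3 to compound 4, 2.3-fold (0.36 log units) apart, within the scatter of two such steps Fluoro in place of hydrogen, read on the 2-(dimethylamino)ethyl chain, gives a 4.1-fold lower number from compound 1 to compound 4 (0.62 log units; beyond the scatter), the only step here beyond the scatter, yet it also cannot be separated from the same change on the 3-(dimethylamino)propyl chain: the same change on two cores in this assay, a 1.8-fold lower number (0.26 log units; within the scatter) from compound 2 to compound 3 and a 4.1-fold lower number (0.62 log units; beyond the scatter) from compound 1 to compound 4, 2.3-fold (0.36 log units) apart, within the scatter of two such steps The chain change therefore carries across these two cores without a measurable difference, but two pairs show neither a shared direction for it nor any dependence on the core.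

From the compounds shown here alone, it remains open whether the fluoro step keeps this size on a longer chain such as 4-(dimethylamino)butyl. A diethylamino end group, or chloro in place of fluoro, would also test how far these steps carry.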